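Swapping the aminomethyl arm for an ester-bearing chain

A few compounds are considered here, and "the series" means these few. Any claim that something is new, unique, unknown or untested is made for them only; others in the source may bear on it.

Measured so far:
compound 1 `COc1ccc(-c2nc(CN)sc2-c2ccc(OC)cc2)cc1` gives 7.7 uM
compound 2 `COc1ccc(-c2nc(C(=O)N3CCN(C(=O)NC(C)C)CC3)sc2-c2ccc(OC)cc2)cc1` gives 15 uM

In a functional assay (aorta) with Rattus norvegicus as the target (a higher number here means that more compound is needed for the effect, a lower number that less compound is needed), compound 1 has the lower of the two numbers, but compound 2 sits close to it, within the usual scatter, so neither can be called stronger. Compound 3 `CCOC(=O)/C=C/c1nc(-c2ccc(OC)cc2)c(-c2ccc(OC)cc2)s1` carries one change from compound 1: 2-(ethoxycarbonyl)ethenyl in place of aminomethyl on an aromatic carbon. For the measured compounds named here, no measured pair shows what such a swap does here. Since two very different groups at that position gave similar numbers for compound 1 and compound 2, only a small step in this assay is expected in either direction. The expected step is a 1.3-fold higher number from compound 1 to compound 3 (0.11 log units; within the scatter). Compound 3 is therefore estimated at 10 uM, ranging from 3 uM to 30 uM.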

Compound 3, concentration for half-maximal effect: > 100 uM
Compound 3 was reported as a limit; the forecaster's own chance of this, stated with the estimate: 15%; middle value at least 10-fold (1.00 log units) from the limit.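

In this assay, 2-(ethoxycarbonyl)ethenyl in place of aminomethyl gives an at least 12-fold higher number from compound 1 to compound 3 (1.11 log units; beyond the scatter), so this position does not accept every group equally. The reading for compound 3 is a limit, not a number: the limit of > 100 uM in this assay, at which 1 of the 3 values shown sits.

The compounds shown do not separate the ester from the double bond, as both enter together in one change. Going by these compounds, how a carboxylic acid or a longer amine chain at this position would behave also remains open.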